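Replacing 4-chlorophenyl with 3-fluorophenyl at the low end

A few compounds are considered here, and "the series" means these few. Any claim that something is new, unique, unknown or untested is made for them only; others in the source may bear on it.

Of the compounds shown here, two have been measured so far in a functional assay on MCF7 cells (Homo sapiens) for inhibition, read by MTT assay, with a stated time of 48 h, tested at 10 uM; on this read-out higher numbers stand for more inhibition of growth at the one concentration tested and lower numbers for less inhibition of growth. In this assay compound 1 (`Cc1cc(=O)c2c(O)cc(OCc3ccc([N+](=O)[O-])cc3)c([C@H]3CCN(C)C[C@H]3O)c2o1`) gives 39%. Compound 2 (`CN1CC[C@H](c2c(O)cc(O)c3c(=O)cc(/C=C/c4ccc(Cl)cc4)oc23)[C@H](O)C1`) gives 10%, the lower of the two numbers, and its gap to compound 1 lies beyond the scatter.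

Compound 3 (`CN1CC[C@H](c2c(O)cc(O)c3c(=O)cc(/C=C/c4cccc(F)c4)oc23)[C@H](O)C1`) has yet to be measured. It departs from compound 2 in one place: 3-fluorophenyl in place of 4-chlorophenyl on a double-bonded chain carbon bound to a double-bonded chain carbon. Here, 3-fluorophenyl stands in place of 4-chlorophenyl on a double-bonded chain carbon bound to a double-bonded chain carbon. Cut one bond further out, the same difference reads 2-(4-chlorophenyl)ethenyl to 2-(3-fluorophenyl)ethenyl.

For the measured compounds named here, no measured pair shows what such an exchange does, so the expectation stays close to the starting point, compound 2 at 10%. The estimated step, a number 3 percentage points higher from compound 2 to compound 3 (within the scatter), is slightly upward and is not expected to go beyond the scatter. In this assay the estimate for compound 3 is 13%, with an expected range from 3% to 27%.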

Compound 3, percent growth inhibition at one concentration: 83%
Compound 3: middle estimate off by 70 percentage points, on the low side; measured number above the stated range.
By their numbers in this assay, from the lowest: compound 2; then compound 1; then compound 3.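

In this assay, for the compounds shown here, the exchange of 4-chlorophenyl for 3-fluorophenyl on a double-bonded chain carbon bound to a double-bonded chain carbon brings a large rise, a number 73 percentage points higher from compound 2 to compound 3 (beyond the scatter), so this position, which the earlier compounds left untested, clearly bears on growth inhibition at the one concentration tested. The counts do not separate the two groups: each has 7 heavy atoms and one six-membered aromatic ring of carbon only, with no hydrogen-bond donors or acceptors and no net charge, so the step goes with the identity of the halogen, its place on the ring, or both. Nothing at hand explains why so small an exchange is followed by so large a step.

The compounds shown leave open which of these two differences carries the step, a question that a 4-fluorophenyl or a 3-chlorophenyl group on the same chain would help to settle. They also leave open whether a halogen is needed at all, which an unsubstituted phenyl or a 3-methoxyphenyl group in the same place would test.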